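This account rests on a few compounds, and the source may have more. Where it says the series, first, only, none or still open, it means among the compounds named here.

Working notes on the series. Four compounds share one core, each carrying a 3-hydroxyphenyl group and a chlorophenyl group together with a third aromatic ring. Compound 1 `Oc1cccc(-c2cc(-c3cccnc3)nc(-c3cccc(Cl)c3)c2)c1` is recorded in a functional assay on DU-145 cells (Homo sapiens) for cytotoxicity, read by CCK-8 assay and cell counting, with a stated time of 2 days (on this read-out lower numbers stand for stronger inhibition and higher numbers for weaker inhibition), as "not determined" (no result reported). Compound 2 `Oc1cccc(-c2cc(-c3ccncc3)nc(-c3cccc(Cl)c3)c2)c1` likewise stands in this assay at "not determined" (no result reported), so compound 2 has no single number to go on, and compound 1 is the one further entry without a number. The only figure in hand comes from compound 3 `Oc1cccc(-c2cc(-c3ccc(Cl)cc3)nc(-c3cccnc3)c2)c1`, which in this assay gives 26800 nM, a weak result. Within the data shown here, no step between measured compounds can be drawn from these entries.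

Compound 4 `Oc1cccc(-c2cc(-c3cccc(Cl)c3)nc(-c3ccco3)c2)c1` differs from compound 2 by furan-2-yl in place of pyridin-4-yl on an aromatic carbon. Among the measured compounds shown here, with no number for compound 2 and no measured pair to compare, no direction can be assigned to this change in this assay; the one anchor, compound 3, points to weak activity across the set. Compound 4 is therefore expected to give about 25000 nM in this assay, within a range from 6000 nM to 90000 nM.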

Compound 4, half-maximal inhibitory concentration: 2020 nM
Beside the measured number, compound 4's estimate is 12-fold (1.09 log units) above it, outside the stated range (below it).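

No new step can be read from compound 4, as compound 2, its one-place neighbour, has no single number in this assay. The compounds shown leave open how furan-2-yl compares with pyridin-4-yl at this position. No supporting data bear on the result of compound 4.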